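A few compounds are considered here, and "the series" means these few. Any claim that something is new, unique, unknown or untested is made for them only; others in the source may bear on it.

Working notes on the series. Going by the values given here, in a functional assay on A549 cells (Homo sapiens) for antiproliferative activity, read by MTT assay, with a stated time of 48 h (on this read-out lower numbers stand for stronger inhibition and higher numbers for weaker inhibition), compound 3 `COc1ccc(-c2cn3cc(C4=CCN(C(=O)c5ccccc5C(F)(F)F)CC4)ccc3n2)cc1OC` gives 2550 nM, the lowest of the three numbers measured so far. Compound 2 `COc1ccc(-c2cn3cc(C4=CCN(C(=O)c5cccc(C(F)(F)F)c5)CC4)ccc3n2)cc1OC` gives 3690 nM, and the step of a 1.4-fold lower number from compound 2 to compound 3 (0.16 log units; within the scatter) lies within the scatter, so no order between these two is claimed. Compound 1 `COc1ccc(-c2cn3cc(C4=CCN(C(=O)c5ccc(Cl)cc5)CC4)ccc3n2)cc1OC` gives 8970 nM; the steps of a 2.4-fold lower number from compound 1 to compound 2 (0.39 log units; beyond the scatter) and a 3.5-fold lower number from compound 1 to compound 3 (0.55 log units; beyond the scatter) are both beyond the scatter and modest in size.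

Compound 4 `COc1ccc(-c2cn3cc(C4=CCN(S(=O)(=O)c5ccccc5)CC4)ccc3n2)cc1OC` differs from compound 3 in one place: phenylsulfonyl in place of (2-(trifluoromethyl)phenyl)carbonyl on an amine nitrogen in a ring. Among the compounds with values here, none of the measured steps bears directly on this change, since each of them only exchanges one aryl group for another on a carbonyl carbon while the carbonyl itself remains. Those exchanges moved the numbers modestly at most, as the step of a 3.5-fold lower number from compound 1 to compound 3 (0.55 log units; beyond the scatter) shows. Compound 4 also lacks the trifluoromethyl group carried by compounds 2 and 3, and compound 1, which lacks it as well, shows the highest number of the three. Within the data shown here, a somewhat higher number is therefore expected for compound 4, with wide uncertainty given that no measured pair tests a sulfonyl in place of a carbonyl; the expected step is a 2.2-fold higher number from compound 3 to compound 4 (0.33 log units; beyond the scatter). In this assay compound 4 is estimated at 5500 nM, with a range from 1500 nM to 20000 nM.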

Compound 4, half-maximal inhibitory concentration: 7660 nM
Beside the measured number, compound 4's estimate is 1.4-fold (0.14 log units) below it; the measured number falls inside the stated range.
By their numbers in this assay, from the lowest: compounds 3 and 2 (each within the scatter of the next); then compounds 4 and 1 (each within the scatter of the next).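

In this assay, going by these compounds alone, phenylsulfonyl on the amine nitrogen in a ring gives the first reading of a group other than an aryl carbonyl at this place, and the size of the change depends on which carbonyl group leaves. Against the two trifluoromethyl-bearing groups the exchange raises the number modestly, with a 3.0-fold higher number from compound 3 to compound 4 (0.48 log units; beyond the scatter) and a 2.1-fold higher number from compound 2 to compound 4 (0.32 log units; beyond the scatter). Against (4-chlorophenyl)carbonyl, however, a 1.2-fold lower number from compound 1 to compound 4 (0.07 log units; within the scatter) gives no separation, so the series shows no general penalty for phenylsulfonyl, and no measurement in hand accounts for these steps.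

The exchange from compound 3 to compound 4 swaps the carbonyl for a sulfonyl and removes the trifluoromethyl group in a single step, so the two contributions remain unseparated; a (2-(trifluoromethyl)phenyl)sulfonyl group on the same nitrogen would pull them apart. Going by these compounds, it also remains open how this nitrogen responds to a group without an aromatic ring, such as a short chain ending in an amine or a carboxylic acid.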